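Thiazolidinedione series: bromo for ethoxy on the aryl ether

The compounds below may be only part of what the source reports. "The series", "measured", "known", "first", "only" and "open" are said of these compounds alone.

Working notes on the series. Going by the values given here, compound 2 `C=CCOc1c(C)c(C)c2c(c1C)CCC(C)(COc1ccc(/C=C3\SC(=O)NC3=O)cc1OCC)O2` sits at the top of the two numbers measured so far: in a functional assay on MCF7 cells (Homo sapiens), tested at 7.5 uM (on this read-out higher numbers stand for a weaker effect at the one concentration tested and lower numbers for a stronger effect), compound 2 gives 75%. Among the compounds with values here, its nearest neighbour is compound 1 `C=CCOc1c(C)c(C)c2c(c1C)CCC(C)(COc1ccc(/C=C3\SC(=O)NC3=O)cc1C)O2`, which in this assay gives 8%; the single measured step, a number 67 percentage points higher from compound 1 to compound 2 (beyond the scatter), arose from ethoxy in place of methyl on an aromatic carbon. Compound 3 `C=CCOc1c(C)c(C)c2c(c1C)CCC(C)(COc1ccc(/C=C3\SC(=O)NC3=O)cc1Br)O2` is next to be measured; it differs from compound 2 as follows: bromo in place of ethoxy on an aromatic carbon. Within the data shown here, no measured step shows bromo at this position, so the only bearing is indirect: the ethoxy that enters in the step to compound 2 is the group that now leaves. An intermediate value, well below compound 2 but not reaching compound 1, is therefore expected, with wide uncertainty. For compound 3 the estimate in this assay is 35%, within 8% to 70%, meaning an expected step of a number 40 percentage points lower from compound 2 to compound 3 (beyond the scatter).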

Compound 3, a percentage reported as activity, at one concentration (the size of the read-out at that concentration, not a potency): 105%
Beside the measured number, compound 3's estimate is 70 percentage points below it; measured number outside the range, above it.
By their numbers in this assay, from the lowest: compound 1; then compound 2; then compound 3.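

In this assay, replacing ethoxy with bromo does not move the number back towards compound 1: the result is a number 30 percentage points higher from compound 2 to compound 3 (beyond the scatter), so a group of 1 heavy atom in place of one of 3 heavy atoms gives the weaker effect here. Against methyl the change is a number 97 percentage points higher from compound 1 to compound 3 (beyond the scatter), which places both ethoxy and bromo on the weak side of methyl on this aromatic carbon and shows that a change at this single position can span nearly the whole range seen in the series. No available evidence bears on why this position responds in this way.

Going by these compounds, three groups at one position give no trend, so it remains open whether methyl is an isolated favourable case. Where an ethyl, a chloro or an amine would fall also remains open.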